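The source may report more compounds than this note shows. Statements on the series, on what has been measured and on what is new or still open speak of the compounds shown alone.

Three members of the series have numbers in a physicochemical assay for solubility, read by HPLC, measured as thermodynamic solubility, with a stated time of 4 h, at pH 6.8; on this read-out lower numbers stand for lower solubility and higher numbers for higher solubility. Compound 1 `Cc1ccc(Oc2ccc3nc(COc4cccc(C(=O)O)c4)n(C)c3n2)c(C)c1` gives 0.9 ug/mL, compound 2 `Cn1c(COc2cccc(C(=O)O)c2)nc2cnc(Oc3ccc4c(c3)OCC4)cc21` gives 79 ug/mL, and compound 3 `Cn1c(COc2cccc(C(=O)O)c2)nc2ccc(Oc3cc(Cl)ccn3)cc21` gives 11 ug/mL. Compound 3 thus stands second highest of the three: compound 2 sits above it by a gap beyond the scatter, and compound 1 sits below it by a gap also beyond the scatter. Compound 4 `Cc1cc(Cl)cnc1Oc1ccc2nc(COc3cccc(C(=O)O)c3)n(C)c2c1` has not yet been measured in this assay. It differs from compound 3 in one place: 5-chloro-3-methylpyridin-2-yl in place of 4-chloropyridin-2-yl on an oxygen on an aromatic ring. Among the measured compounds shown here, no pair of measured compounds shares this change, so the expectation rests on the spread of the series alone. For compound 4 a modest downward step a 2.8-fold lower number from compound 3 to compound 4 (0.44 log units; beyond the scatter) is expected, beyond the scatter. It should stay well short of the low end set by compound 1 at 0.9 ug/mL. Compound 4 is estimated at 4 ug/mL, with a range from 1.5 ug/mL to 12 ug/mL.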

Compound 4, solubility: 3.9 ug/mL
Compound 4: the middle estimate sits 1.0-fold (0.01 log units) above what was measured, within the range that was stated.
By their numbers in this assay, from the lowest: compound 1; then compound 4; then compound 3; then compound 2.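

In this assay, among the compounds shown here, the change from (4-chloropyridin-2-yl)oxy to (5-chloro-3-methylpyridin-2-yl)oxy provides the first one-place comparison: a 2.8-fold lower number from compound 3 to compound 4 (0.45 log units; beyond the scatter). The number therefore moves with the group at this place, on an oxygen on an aromatic ring. No measured evidence bears on what lies behind this step.

From the compounds shown here alone, the entering group differs in both the place of its chloro and an added methyl, so the share of each remains open. Also open, going by these compounds, is how the number would respond to an amine in place of the chloro.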